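The compounds below may be only part of what the source reports. "The series", "measured", "known", "first", "only" and "open" are said of these compounds alone.

Compound 1 `Cc1ccc(-n2cc(CNC(=O)c3cccc4c3cnn4C(C)C)nn2)cc1C`: in a functional assay on MGC-803 cells (Homo sapiens) for inhibition, read by MTT assay, with a stated time of 72 h (on this read-out lower numbers stand for stronger inhibition and higher numbers for weaker inhibition), compound 1 gives > 40000 nM, which is a limit of the assay rather than a number.
Compound 2 `Cc1ccc(-n2cc(CNC(=O)c3cccc4c3cnn4C(C)C)nn2)c(C)c1`: in this assay compound 2 gives > 40000 nM, likewise a limit.
Compound 3 `CCc1ccc(-n2cc(CNC(=O)c3cccc4c3cnn4C(C)C)nn2)cc1`: in this assay compound 3 gives > 40000 nM, again a limit.

Compound 3 thus stands at the limit shared by every measured compound here (the limit of > 40000 nM in this assay, at which 3 of the 3 values shown sit); no number is known for it, only that the assay did not reach one. The three compounds have the same core and differ only in the group carried on an aromatic nitrogen of the five-membered ring. The steps a step that the two limits leave unreadable from compound 1 to compound 2, a step that the two limits leave unreadable from compound 1 to compound 3 and a step that the two limits leave unreadable from compound 2 to compound 3 are all unreadable: with both ends at a limit, their size cannot be told.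

Compound 4 `CC(C)n1ncc2c(C(=O)NCc3cn(Cc4ccccc4)nn3)cccc21` differs from compound 3 by benzyl in place of 4-ethylphenyl on an aromatic nitrogen. Going by the values given here, all three measured steps bear on this change, since each swaps the group at this same place, but none has a readable size, so they give no direction to expect in this assay; the only guidance is that every variation at this place so far stayed at the limit (the limit of > 40000 nM in this assay, at which 3 of the 3 values shown sit). Compound 4 is therefore estimated to give about 40000 nM, within 15000 nM to 100000 nM. The expected step of a number no higher from compound 3 to compound 4 (the limit leaves the size open) is a guess around the limit, most likely reported again only as a limit.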

Compound 4, half-maximal inhibitory concentration: 14300 nM
For compound 4 the middle estimate is 2.8-fold (0.45 log units) above the measured one; measured number outside the range, below it.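

The change to benzyl gives an at least 2.7-fold lower number from compound 3 to compound 4 (0.44 log units; beyond the scatter) and an at least 2.7-fold lower number from compound 2 to compound 4 (0.44 log units; beyond the scatter) and also an at least 2.7-fold lower number from compound 1 to compound 4 (0.44 log units; beyond the scatter) in this assay as its result. Going by these compounds alone, the group on the aromatic nitrogen can therefore shift the number, which the earlier compounds, all stuck at one limit, could not show. Each of these steps gives only a smallest possible size, and the steps among compound 1, compound 2 and compound 3 still cannot be read, so those three groups stay unranked, with the assay limit as the only shared fact about them: the limit of > 40000 nM in this assay, at which 3 of the 4 values shown sit.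

The compounds shown cannot separate two features of the change, since benzyl both differs from the other groups in how its aromatic ring is attached and carries no methyl or ethyl group on that ring. They also leave open how the number would respond to a longer chain such as 2-phenylethyl, or to an amine or a carboxylic acid on the benzyl ring.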